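Terminal alkyne replacing the trifluoromethyl tail

A few compounds are considered here, and "the series" means these few. Any claim that something is new, unique, unknown or untested is made for them only; others in the source may bear on it.

Measured compounds:
compound 1, `CCCCCCCCCCCCCCc1ccccc1C(SCCC(=O)O)SCCC(=O)O`, 1250 nM
compound 2, `CCCCCCCCc1ccccc1C(SCCC(=O)O)SCCC(=O)O`, 5670 nM
compound 3, `O=C(O)CCSC(SCCC(=O)O)c1ccccc1CCCCCCCCCCCC(F)(F)F`, 147 nM

In an assay on membranes from lung (Cavia porcellus) for binding affinity to cysteinyl leukotriene receptor (Homo sapiens) (on this read-out lower numbers stand for stronger inhibition and higher numbers for weaker inhibition), compound 3 gives the lowest number of the three, with an 8.5-fold lower number from compound 1 to compound 3 (0.93 log units; beyond the scatter) and a 39-fold lower number from compound 2 to compound 3 (1.59 log units; beyond the scatter). Compound 4, `C#CCCCCCCCCCCc1ccccc1C(SCCC(=O)O)SCCC(=O)O`, differs from compound 3 by ethynyl in place of 2,2,2-trifluoroethyl on a saturated chain carbon, ten or more bonds along the chain from an aromatic carbon. The step that bears on it is an 8.5-fold lower number from compound 1 to compound 3 (0.93 log units; beyond the scatter), where bringing in the fluorinated chain end lowered the number; compound 4 gives that fluorinated end up again while keeping a chain of similar length, so the expectation is a move back toward compound 1, as an 8.2-fold higher number from compound 3 to compound 4 (0.91 log units; beyond the scatter). Compound 4 is therefore estimated at 1200 nM, with a range from 400 nM to 3500 nM.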

Compound 4, inhibition constant: 141 nM
Estimate against measurement, compound 4: 8.5-fold (0.93 log units) above; measured number below the stated range.
By their numbers in this assay, from the lowest: compounds 4 and 3 (each within the scatter of the next); then compound 1; then compound 2.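

In this assay the ethynyl chain end matches the 2,2,2-trifluoroethyl end (a 1.0-fold lower number from compound 3 to compound 4 (0.02 log units; within the scatter)), so the lower numbers do not depend on fluorine. The gain over the plain alkyl chains holds for the alkyne too (an 8.9-fold lower number from compound 1 to compound 4 (0.95 log units; beyond the scatter); a 40-fold lower number from compound 2 to compound 4 (1.60 log units; beyond the scatter)). No evidence given here accounts for the match between the two chain ends.

As far as these compounds go, it remains open whether a nitrile or a hydroxyl at the chain end would give a similar number. Also open, from the compounds shown here alone, is whether a longer chain carrying the ethynyl end would do so.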